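The source may hold more compounds than are shown below. What is called first, only, known or untested is meant among the compounds shown, and "the series" means these compounds.

Values in an ADME assay on microsomes from liver (Homo sapiens) for metabolic stability (a higher number here means that the compound lasts longer, a lower number that the compound disappears faster), so far

compound 1 `COc1cc(OCc2cccc(-c3ccc(C(F)(F)F)cn3)c2)c2cc(-c3cn4nc(OC)sc4n3)oc2c1` gives 0.733 h
compound 2 `CNC(=O)c1ccc(-c2nc(COc3cc(OC)cc4oc(-c5cn6nc(OC)sc6n5)cc34)cs2)cc1` gives 0.983 h
compound 3 `COc1cc(OCc2csc(-c3ccc(S(C)(=O)=O)cc3)n2)c2cc(-c3cn4nc(OC)sc4n3)oc2c1` gives 1.22 h

Compound 1 lies within the usual scatter of both compound 2 and compound 3, so the three values set no order among them. Not yet measured is compound 4 `COc1cc(OCc2cccc(OCc3ccccc3)c2)c2cc(-c3cn4nc(OC)sc4n3)oc2c1`, which differs from compound 1 in one place: benzyloxy in place of 5-(trifluoromethyl)pyridin-2-yl on an aromatic carbon. In words, benzyloxy stands in place of 5-(trifluoromethyl)pyridin-2-yl on an aromatic carbon of a six-membered aromatic ring of carbon only, meta to a large group.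

Going by the values given here, only one measured step is available, a 1.2-fold higher number from compound 2 to compound 3 (0.09 log units; within the scatter), and it is within the scatter. Among the compounds with values here, it exchanges methylsulfonyl for methylcarbamoyl, so it bears on this change only indirectly, and no measured compound carries benzyloxy. No step beyond the scatter is therefore expected in this assay, and no direction is favoured. The estimate amounts to an expected 1.0-fold lower number from compound 1 to compound 4 (0.02 log units; within the scatter). Compound 4 is expected at 0.7 h, with an estimated range of 0.35 h to 1.3 h.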

Compound 4, half-life: 1.43 h
Estimate against measurement, compound 4: 2.0-fold (0.31 log units) below, outside the stated range (above it).
By their numbers in this assay, from the lowest: compounds 1, 2, 3 and 4 (each within the scatter of the next).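

In this assay, a 2.0-fold higher number from compound 1 to compound 4 (0.29 log units; within the scatter) accompanies benzyloxy in place of 5-(trifluoromethyl)pyridin-2-yl on an aromatic carbon, meta to a large group. Going by these compounds alone, this is the first step read at this place, as the only earlier step concerns the exchange of methylcarbamoyl and methylsulfonyl elsewhere in the structure. Here, a pyridine ring carrying trifluoromethyl and a benzyloxy group with a ring of carbon only can stand at the same position without a step beyond the scatter, and nothing measured here offers an explanation for the numbers.

From the compounds shown here alone, whether an amine or a carboxylic acid at this place would give a step beyond the scatter remains open. Also open, going by these compounds, is whether benzyloxy would give a similar result on the structures of compound 2 and compound 3.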